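Trading chloro for trifluoromethyl in a cytotoxicity series

The compounds below may be only part of what the source reports. "The series", "measured", "known", "first", "only" and "open" are said of these compounds alone.

Of the compounds shown here, three sharing one core have been tested in an ADME assay on HEp-2 cells (Homo sapiens) for cytotoxicity; on this read-out higher numbers stand for lower toxicity in this test and lower numbers for higher toxicity in this test. Compound 1 `Cc1ccc(C)c(NC(=O)[C@@H]2CCCN2S(=O)(=O)c2cccc3cccnc23)c1` gives 30900 nM. For compound 2 `Cc1cccc(C)c1NC(=O)[C@@H]1CCCN1S(=O)(=O)c1cccc2cccnc12` the assay reports only a limit, > 50000 nM. Compound 3 `Cc1ccc(Cl)cc1NC(=O)[C@@H]1CCCN1S(=O)(=O)c1cccc2cccnc12` gives 10000 nM, the lowest number of the three.

Compound 4 `Cc1ccc(C(F)(F)F)cc1NC(=O)[C@@H]1CCCN1S(=O)(=O)c1cccc2cccnc12` has not yet been measured. It carries trifluoromethyl in place of chloro on an aromatic carbon, para to a methyl group: trifluoromethyl in place of chloro on an aromatic carbon.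

The closest evidence comes from a change at that same place, chloro in place of methyl, which gave a 3.1-fold lower number from compound 1 to compound 3 (0.49 log units; beyond the scatter). The step of an at least 5.0-fold lower number from compound 2 to compound 3 (0.69 log units; beyond the scatter) is larger, but it alters the ring in more than one place and so bears less directly. For the measured compounds named here, no trifluoromethyl compound has been measured yet, so the size of this swap cannot be read directly from the data. A modest change at most seems likely, with no clear direction. The expected result is a 1.1-fold higher number from compound 3 to compound 4 (0.04 log units; within the scatter), which would lie within the usual scatter. For compound 4 the estimated value in this assay is 11000 nM, with an expected range from 4500 nM to 27000 nM.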

Compound 4, half-maximal cytotoxic concentration: 4800 nM
Compound 4: middle estimate off by 2.3-fold (0.36 log units), on the high side, within the range that was stated.
By their numbers in this assay, from the lowest: compound 4; then compound 3; then compound 1. At a limit, above all of these: compound 2.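

In this assay trifluoromethyl in place of chloro gives a 2.1-fold lower number from compound 3 to compound 4 (0.32 log units; beyond the scatter) and so is not a neutral swap at this place, para to a methyl group. Set against methyl at the same place, trifluoromethyl gives a 6.4-fold lower number from compound 1 to compound 4 (0.81 log units; beyond the scatter) and, together with the earlier chloro step, this puts all three pairs of these groups beyond the usual scatter. The number therefore falls from methyl through chloro to trifluoromethyl, which means higher toxicity in this test, though this order is shown for these three groups only.

Going by these compounds, whether a methoxy group, an amine or a carboxylic acid at this place would lower the number further or raise it again stays open. Nothing measured here explains the order of these three groups.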